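Benzylamide series: from tert-butyl to butyl side chain

This account rests on a few compounds, and the source may have more. Where it says the series, first, only, none or still open, it means among the compounds named here.

In a functional assay on the whole organism (strain NMRI) with Mus musculus as the target, in the maximal electroshock model, with a stated time of 30 min (a higher number here means that more compound is needed for the effect, a lower number that less compound is needed), compound 1 `C#CCOCC(N)C(=O)NCc1ccccc1` gives 46 mg/kg and compound 2 `CC(C)(C)[C@@H](N)C(=O)NCc1ccccc1` gives 13 mg/kg. Of these two numbers compound 2 holds the lowest, so less of it is needed for the effect, and compound 1 sits beyond the scatter from it. Compound 3 `CCCC[C@@H](N)C(=O)NCc1ccccc1` is not yet measured in this assay. Against compound 2 the change is butyl in place of tert-butyl on a saturated chain carbon bound to an amine nitrogen and a carbonyl carbon. Going by the values given here, no measured pair shows a step of this kind, so there is nothing to read the direction from; the expectation therefore rests on the two values alone and on the change itself. For compound 3 the number is expected to move upward by a 2.3-fold higher number from compound 2 to compound 3 (0.36 log units; beyond the scatter), a step judged beyond the scatter. The estimate for compound 3 is 30 mg/kg, with a range from 12 mg/kg to 80 mg/kg.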

Compound 3, dose for half-maximal effect: 23 mg/kg
Estimate against measurement, compound 3: 1.3-fold (0.12 log units) above; the measured number falls inside the stated range.
By their numbers in this assay, from the lowest: compounds 2, 3 and 1 (each within the scatter of the next, the first and the last beyond it).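

In this assay, going by these compounds alone, butyl in place of tert-butyl on a saturated chain carbon bound to an amine nitrogen and a carbonyl carbon gives a 1.8-fold higher number from compound 2 to compound 3 (0.25 log units; within the scatter), the first step that can be read directly. The two groups hold the same atoms, joined differently, and this rearrangement does not separate compound 2 from compound 3 in this assay, so at this position both groups fit a number within the scatter of each other. No measurement at hand offers an explanation for this result.

Going by these compounds, whether a longer chain such as hexyl, a cyclohexyl ring or a chain ending in a hydroxyl group would stay within the scatter of compound 2 remains open. So does the reading of the mirror-image forms of compound 2 and compound 3.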